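A few compounds are considered here, and "the series" means these few. Any claim that something is new, unique, unknown or untested is made for them only; others in the source may bear on it.

Notes on the series. Compound 1 `O=C(Nc1ccc(Oc2ccnc3[nH]ccc23)c(F)c1)c1cc2cccnc2n(-c2ccc(Cl)cc2)c1=O` gives 82 nM in a functional assay on HT-29 cells (Homo sapiens) for antiproliferative activity, read by MTT assay, with a stated time of 72 h; a higher number here means a weaker inhibitor, a lower number a stronger inhibitor. Compound 2 `O=C(Nc1ccc(Oc2ccnc3[nH]ccc23)c(F)c1)c1cc2cccnc2n(-c2ccc(Br)cc2)c1=O` carries bromo in place of chloro on an aromatic carbon and in this assay compound 2 gives 120 nM; the step is a 1.5-fold higher number from compound 1 to compound 2 (0.17 log units; within the scatter). Compound 3 `Cn1ccc2c(Oc3ccc(NC(=O)c4cc5cccnc5n(-c5ccc(Cl)cc5)c4=O)cc3)ccnc21` stands on a different core; the difference between the two cores is not broken down here. In this assay compound 3 gives 730 nM, the highest number of the three. For the measured compounds named here, compound 4 `Cn1ccc2c(Oc3ccc(NC(=O)c4cc5cccnc5n(-c5ccc(Br)cc5)c4=O)cc3)ccnc21` is compound 3 with bromo in place of chloro on an aromatic carbon, the same change at the same place as the one from compound 1 to compound 2. Going by the values given here, the expected step is a 1.4-fold higher number from compound 3 to compound 4 (0.14 log units; within the scatter), which rests on a 1.5-fold higher number from compound 1 to compound 2 (0.17 log units; within the scatter) as the only measured instance of the change. Compound 4 is therefore expected to give 1000 nM in this assay, with the estimate spanning 450 nM to 2400 nM.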

Compound 4, half-maximal inhibitory concentration: 690 nM
Estimate against measurement, compound 4: 1.4-fold (0.16 log units) above; low and high end bracket the measured number.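

In this assay, the step for bromo in place of chloro on this core is a 1.1-fold lower number from compound 3 to compound 4 (0.02 log units; within the scatter) and so shows no measurable effect of the change here. Set beside the earlier step, the change carries from one core to the other without a difference that can be told apart: the same change on two cores in this assay, a 1.5-fold higher number (0.17 log units; within the scatter) from compound 1 to compound 2 and a 1.1-fold lower number (0.02 log units; within the scatter) from compound 3 to compound 4, 1.5-fold (0.19 log units) apart, within the scatter of two such steps.
For the compounds shown here, this rests on two pairs and one exchange at one place, so it shows only that these two cores do not separate this change, not that other cores or other groups would behave alike.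

Open, from the compounds shown here alone, is how an amine, a carboxylic acid or a longer chain in place of the halogen on the phenyl ring would read. Also open, going by these compounds, is which part of the difference between the two cores goes with the higher number of compound 3.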